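Replacing a carbonyl-linked group in compound 3

This account rests on a few compounds, and the source may have more. Where it says the series, first, only, none or still open, it means among the compounds named here.

Compound 1 `COc1cc(N2CCN(C(=O)C3CCC(O)CC3)CC2)ccc1Nc1nc(NC2CCCCC2)c2nc[nH]c2n1` gives 19000 nM in a physicochemical assay for solubility, measured as kinetic solubility, at pH 7.4; on this read-out lower numbers stand for lower solubility and higher numbers for higher solubility
Compound 2 `COc1cc(N2CCN(C(=O)N3CCN(C)CC3)CC2)ccc1Nc1nc(NC2CCCCC2)c2nc[nH]c2n1` gives 75000 nM in this assay
Compound 3 `COc1cc(N2CCN(C(=O)N3CCC(O)C3)CC2)ccc1Nc1nc(NC2CCCCC2)c2nc[nH]c2n1` gives 19000 nM in this assay

Compound 3 stands level with compound 1, and together they hold the lowest of the three numbers. The gap to the remaining compound is a 3.9-fold lower number from compound 2 to compound 3 (0.60 log units; beyond the scatter) and is the furthest compound 3 lies from any other. Compound 4 `COc1cc(N2CCN(CC3CCOC3)CC2)ccc1Nc1nc(NC2CCCCC2)c2nc[nH]c2n1` is not yet measured. It carries (oxolan-3-yl)methyl in place of (3-hydroxypyrrolidin-1-yl)carbonyl on an amine nitrogen in a ring and so gives up the carbonyl. Among the measured compounds shown here, all three measured compounds keep that carbonyl, and no measured step shows its removal. The nearest guides are exchanges on the carbonyl carbon, which gave no change at the digits printed from compound 1 to compound 3 (within the scatter) in one case and a 3.9-fold higher number from compound 1 to compound 2 (0.60 log units; beyond the scatter) in another. The only move away from the shared level is upward, in compound 2 (75000 nM) when 4-methylpiperazin-1-yl enters. A modest rise is therefore expected, held with little confidence. The estimated step is a 2.1-fold higher number from compound 3 to compound 4 (0.32 log units; beyond the scatter) and no larger move is assumed. Compound 4 is expected at 40000 nM with an estimated range from 12000 nM to 110000 nM in this assay when measured.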

Compound 4, solubility: 5000 nM
The estimate for compound 4 lay 8.0-fold (0.90 log units) above the measured number; measured number outside the range, below it.
By their numbers in this assay, from the lowest: compound 4; then compounds 1 and 3 (each within the scatter of the next); then compound 2.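

Every earlier exchange sat on the carbonyl carbon, and none took the number in this assay below the level shared by two of the compounds. With the carbonyl gone from the amine nitrogen in the ring and (oxolan-3-yl)methyl there instead, the number falls by the same printed size against both of those compounds (a 3.8-fold lower number from compound 3 to compound 4 (0.58 log units; beyond the scatter)) (a 3.8-fold lower number from compound 1 to compound 4 (0.58 log units; beyond the scatter)), and by a large step against the (4-methylpiperazin-1-yl)carbonyl compound (a 15-fold lower number from compound 2 to compound 4 (1.18 log units; beyond the scatter)). The direction is therefore downward for all three exchanges, though nothing available explains the fall. The carbonyl, the hydroxyl and the ring nitrogen of the group that leaves all change at once, so the compounds shown cannot assign the step to any one of them. An (oxolan-3-yl)carbonyl group or a methylene-linked 1-methylpiperidin-4-yl group at this nitrogen would be needed to separate those parts.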